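Alkoxy anilide series: methoxy to ethoxy step

A few compounds are considered here, and "the series" means these few. Any claim that something is new, unique, unknown or untested is made for them only; others in the source may bear on it.

Measured compounds:
compound 1 `COc1ccc(NC(=O)c2cn(-c3ccccc3)nc2-c2ccccc2)cc1` — 1350 nM
compound 2 `CCOc1ccc(NC(=O)c2cn(-c3ccccc3)nc2-c2ccccc2)cc1` — 620 nM
compound 3 `COc1ccc(NC(=O)c2cn(-c3ccccc3)nc2-c2ccc(C)cc2)cc1` — 1450 nM

All three were run in a functional assay on HCT-116 cells (Homo sapiens) for cytotoxicity, read by MTT assay, with a stated time of 48 h; on this read-out higher numbers stand for weaker inhibition and lower numbers for stronger inhibition. The change from compound 1 to compound 2 is methyl in place of hydrogen on a saturated chain carbon bound to an oxygen on an aromatic ring; it gives a 2.2-fold lower number from compound 1 to compound 2 (0.34 log units; beyond the scatter). The cores of compound 1 and compound 3 differ by methyl in place of hydrogen on an aromatic carbon, and that gives a 1.1-fold higher number from compound 1 to compound 3 (0.03 log units; within the scatter), so compound 1 and compound 3 sit together.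

Compound 4 `CCOc1ccc(NC(=O)c2cn(-c3ccccc3)nc2-c2ccc(C)cc2)cc1` is not yet measured. It differs from compound 3 by methyl in place of hydrogen on a saturated chain carbon bound to an oxygen on an aromatic ring, the same change as from compound 1 to compound 2, at the same place. In this assay the step from compound 3 to compound 4 is expected to be about a 2.1-fold lower number from compound 3 to compound 4 (0.32 log units; beyond the scatter), beside the earlier one, because compound 3 gives 1450 nM within the scatter of compound 1 and the same change gave a 2.2-fold lower number from compound 1 to compound 2 (0.34 log units; beyond the scatter). Compound 4 is therefore estimated at 700 nM, between 350 nM and 1500 nM, in this assay.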

Compound 4, half-maximal inhibitory concentration: 780 nM
For compound 4 the middle estimate is 1.1-fold (0.05 log units) below the measured one, and the stated range covers the measured number.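

In this assay, methoxy to ethoxy carries over from the core of compound 1 to the core of compound 3 with a 1.9-fold lower number from compound 3 to compound 4 (0.27 log units; within the scatter), and the two steps agree: the same change on two cores in this assay, a 2.2-fold lower number (0.34 log units; beyond the scatter) from compound 1 to compound 2 and a 1.9-fold lower number (0.27 log units; within the scatter) from compound 3 to compound 4, 1.2-fold (0.07 log units) apart, within the scatter of two such steps. Methyl in place of hydrogen on an aromatic carbon also carries over, now with a 1.3-fold higher number from compound 2 to compound 4 (0.10 log units; within the scatter), and it matches its earlier step: the same change on two cores in this assay, a 1.1-fold higher number (0.03 log units; within the scatter) from compound 1 to compound 3 and a 1.3-fold higher number (0.10 log units; within the scatter) from compound 2 to compound 4, 1.2-fold (0.07 log units) apart, within the scatter of two such steps. These cores differ by a single methyl, and the step on the core of compound 3 lies within the scatter when taken alone, so this does not show that the change would hold on more distant cores.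

On these data alone, whether the alkoxy trend extends to a longer chain such as propoxy remains open. As far as these compounds go, the effect of an amine or a carboxylic acid at that place also remains open.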